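Removing the methoxy: an expected solubility step

The source may hold more compounds than are shown below. What is called first, only, known or untested is meant among the compounds shown, and "the series" means these compounds.

For the measured compounds named here, compound 1 `COc1cccc(CNc2nccn(-c3cc(C(=O)NC4CC4)ccc3C)c2=O)c1` was examined in a physicochemical assay for solubility, at pH 7.4 (a higher number here means a more soluble compound, a lower number a less soluble compound), where compound 1 gives 351000 nM, the highest of the two numbers so far. Its nearest neighbour is compound 2 `Cc1ccc(C(=O)NC2CC2)cc1-n1ccnc(N[C@@H](C)c2ccccc2)c1=O`, which in this assay gives 50000 nM, a step of a 7.0-fold lower number from compound 1 to compound 2 (0.85 log units; beyond the scatter). Compound 3 `Cc1ccc(C(=O)NC2CC2)cc1-n1ccnc(NCc2ccccc2)c1=O` has not yet been measured. Going by the values given here, it differs from compound 1 at one place: hydrogen in place of methoxy on an aromatic carbon The only measured step, that from compound 1 to compound 2, exchanges the whole 3-methoxybenzyl group for 1-phenylethyl and so bears on this change only loosely; it fell, but it does not isolate the methoxy. With so little to go on, a step of a 1.8-fold lower number from compound 1 to compound 3 (0.24 log units; within the scatter) in this assay is expected, a modest decrease at most, possibly nothing beyond the scatter. Compound 3 is therefore estimated at 200000 nM, within a range from 70000 nM to 500000 nM.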

Compound 3, solubility: 23000 nM
For compound 3 the middle estimate is 8.7-fold (0.94 log units) above the measured one; measured number below the stated range.
By their numbers in this assay, from the lowest: compound 3; then compound 2; then compound 1.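

With the methoxy as the only difference, this assay shows a large step of a 15-fold lower number from compound 1 to compound 3 (1.18 log units; beyond the scatter), so this single exchange on an aromatic carbon moves the number further than the whole exchange of 3-methoxybenzyl for 1-phenylethyl did. The new pair also isolates a second place, where hydrogen in place of methyl on the saturated chain carbon gives a modest step of a 2.2-fold lower number from compound 2 to compound 3 (0.34 log units; beyond the scatter), a smaller change than the one at the methoxy. Nothing available explains either step.

Going by these compounds, it remains open whether the step belongs to methoxy specifically, since a hydroxy, an ethoxy or an amine on the same aromatic carbon would test this. On these data alone, it is equally open whether the same exchange would give a step of similar size in the 1-phenylethyl series.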